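Replacing the piperazinylsulfonyl group of compound 2

The compounds below may be only part of what the source reports. "The series", "measured", "known", "first", "only" and "open" are said of these compounds alone.

Among the compounds with values here, compound 2 `O=S(=O)(c1ccc([C@H]2CC[C@]3(CC2)OOC2(O3)C3CC4CC(C3)CC2C4)cc1)N1CCNCC1` holds the only number in the pair measured in an ADME assay on microsomes from liver (Homo sapiens) for metabolic stability, read by LC-MS, tested at 1 uM; on this read-out lower numbers stand for slow clearance and higher numbers for fast clearance; in this assay compound 2 gives 16 mL.min-1.g-1. Compound 1 `CC(C)(CN)Oc1ccc([C@H]2CC[C@]3(CC2)OOC2(O3)C3CC4CC(C3)CC2C4)cc1` sits at the lower limit of the assay, reported as < 7 mL.min-1.g-1, so no number is known for it. Within the data shown here, the single measured step, an at least 2.2-fold higher number from compound 1 to compound 2 (0.35 log units; beyond the scatter), rests on that limit, (the limit of < 7 mL.min-1.g-1 in this assay, at which 1 of the 2 values shown sits), and its true size is therefore open at the lower end.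

Compound 3 `NCCS(=O)(=O)CCOc1ccc([C@H]2CC[C@]3(CC2)OOC2(O3)C3CC4CC(C3)CC2C4)cc1` is not yet measured. Its change from compound 2 is 2-((2-aminoethyl)sulfonyl)ethoxy in place of (piperazin-1-yl)sulfonyl on an aromatic carbon. The entering 2-((2-aminoethyl)sulfonyl)ethoxy group, like the 1-(aminomethyl)-1-methylethoxy group of compound 1, is attached through an oxygen and ends in a primary amine, while the sulfonyl of compound 2 is kept within the chain. Among the measured compounds shown here, only the step from compound 1 to compound 2 bears on this, and it points toward lower clearance when an oxygen-linked aminoalkyl chain is present. For the measured compounds named here, the expected step is a 1.6-fold lower number from compound 2 to compound 3 (0.20 log units; within the scatter), a modest fall, though no measured pair tests a sulfonyl placed inside such a chain. For compound 3 the estimate in this assay is 10 mL.min-1.g-1, within a range of 5 mL.min-1.g-1 to 22 mL.min-1.g-1.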

Compound 3, intrinsic clearance in microsomes: 9 mL.min-1.g-1
Beside the measured number, compound 3's estimate is 1.1-fold (0.05 log units) above it; measured number inside the range.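

In this assay, 2-((2-aminoethyl)sulfonyl)ethoxy and (piperazin-1-yl)sulfonyl on this aromatic carbon, para to a large group, are not told apart: the step is a 1.8-fold lower number from compound 2 to compound 3 (0.25 log units; within the scatter) and so an oxygen-linked chain ending in a primary amine can read like the sulfonyl-linked piperazine, which the step from compound 1 to compound 2 alone did not suggest. Compound 1 remains a limit of the assay (< 7 mL.min-1.g-1). Compound 3 adds a measured number for an oxygen-linked chain ending in a primary amine, yet its relation to compound 1 stays unresolved, with an at least 1.2-fold higher number from compound 1 to compound 3 (0.10 log units; that floor lies within the scatter) as the only reading, and that reading rests on a limit: the limit of < 7 mL.min-1.g-1 in this assay, at which 1 of the 3 values shown sits.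

The compounds shown leave open what the sulfonyl inside the chain contributes, a question that a plain alkoxy chain of the same length ending in a primary amine would address. Also open, on these data alone, are how a tertiary amine or a carboxylic acid at the chain end would read in this assay and how far compound 3 truly lies from compound 1.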